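A few compounds are considered here, and "the series" means these few. Any claim that something is new, unique, unknown or untested is made for them only; others in the source may bear on it.

Measured compounds:
compound 1 `COc1cccc2cc(-c3ccccc3)c(O)nc12`; in a functional assay on T47D cells (Homo sapiens) for cytotoxicity, read by colorimetric assay and MTT assay (on this read-out lower numbers stand for stronger inhibition and higher numbers for weaker inhibition), compound 1 gives 10000 nM
compound 2 `COc1ccc(-c2cc3cccc(OC)c3nc2O)cc1`; in this assay compound 2 gives 10000 nM
compound 3 `COc1ccc(-c2cc3c(OC)cc(OC)cc3n(C)c2=O)cc1`; in this assay compound 3 gives 10000 nM

Among the measured compounds shown here, the one single-point step measured so far, no change at the digits printed from compound 1 to compound 2 (within the scatter), involves a methoxy in place of hydrogen on an aromatic carbon and leaves the read-out unchanged within the scatter. Compound 3 stands level with compound 1 and compound 2 at the digits shown, all three sitting at the same value in this assay.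

Compound 4 `COc1ccc(-c2cc3c(OC)cc(OC)cc3n(CC(=O)OCc3ccccc3)c2=O)cc1` is not yet measured. It differs from compound 3 as follows: benzyloxycarbonyl in place of hydrogen on a saturated chain carbon bound to an aromatic nitrogen. For the measured compounds named here, no measured step touches the saturated chain carbon bound to the aromatic nitrogen, so nothing speaks directly to this change. Going by the values given here, the only information is that the three measured compounds, differing on the aromatic carbons and at the lactam nitrogen, all read alike in this assay. Absent any evidence of movement, the expected step of no change at the digits printed from compound 3 to compound 4 (within the scatter) is none beyond the scatter. The estimate for compound 4 in this assay is 10000 nM, with a range from 5000 nM to 20000 nM.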

Compound 4, half-maximal inhibitory concentration: 10000 nM
Compound 4: middle estimate and measured number agree at the digits printed; the measured number falls inside the stated range.
By their numbers in this assay, from the lowest: compounds 1, 2, 3 and 4 (each within the scatter of the next).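

Among the compounds shown here, the first step at this position, on the saturated chain carbon bound to an aromatic nitrogen, reads no change at the digits printed from compound 3 to compound 4 (within the scatter) in this assay as the read-out. The methyl to (benzyloxycarbonyl)methyl difference adds 10 heavy atoms, including a six-membered aromatic ring of carbon only, so a group of this size at this place does not separate compound 4 from compound 3 in this read-out. No supporting data bear on why the two compounds read alike.

Still open, on these data alone, is whether a carboxylic acid or an amine at the end of the chain, or a longer alkyl chain without the benzyl ester, would read apart from compound 3 at this position. With all four compounds level, the series shown does not yet reveal any change that moves this read-out beyond the scatter.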